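The compounds below may be only part of what the source reports. "The series", "measured", "known", "first", "only" and "open" are said of these compounds alone.

Compound 1 `CN(C)CCn1cnnc1-c1cc(Oc2ccc(NC(=O)N/N=C/c3cccc(Cl)c3Cl)cc2F)ccn1`: 72 nM
Compound 2 `CN(C)CCn1cnnc1-c1cc(Oc2ccc(NC(=O)N/N=C/c3ccc(Cl)cc3)cc2F)ccn1`: 320 nM

In a functional assay on NCI-H460 cells (Homo sapiens) for cytotoxicity, read by MTT assay, with a stated time of 72 h (on this read-out higher numbers stand for weaker inhibition and lower numbers for stronger inhibition), compound 2 gives 320 nM, the highest of the two numbers measured; its nearest neighbour, compound 1, gives 72 nM in this assay. Among the measured compounds shown here, the only step measured so far, a 4.4-fold higher number from compound 1 to compound 2 (0.65 log units; beyond the scatter), shows that swapping the ring attached to the carbon with a double bond to nitrogen can shift this assay beyond the usual scatter. Compound 3 `CN(C)CCn1cnnc1-c1cc(Oc2ccc(NC(=O)N/N=C/c3ccc(O)c(F)c3)cc2F)ccn1` is not yet measured. It differs from compound 2 by 3-fluoro-4-hydroxyphenyl in place of 4-chlorophenyl on a carbon with a double bond to nitrogen. For the measured compounds named here, no measured step involves a 3-fluoro-4-hydroxyphenyl group, so the direction of this change cannot be read from the two compounds in hand; the one step measured shows only that this part of the molecule matters. For compound 3 the expectation is therefore a number near that of compound 2, with wide uncertainty, estimated as 350 nM (range 100 nM to 1200 nM). The expected step is a 1.1-fold higher number from compound 2 to compound 3 (0.04 log units; within the scatter).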

Compound 3, half-maximal inhibitory concentration: 2620 nM
For compound 3 the middle estimate is 7.5-fold (0.87 log units) below the measured one; measured number above the stated range.
By their numbers in this assay, from the lowest: compound 1; then compound 2; then compound 3.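

In this assay, changing the ring on the carbon with a double bond to nitrogen can cost far more than the earlier step suggested: 3-fluoro-4-hydroxyphenyl in place of 4-chlorophenyl gives a larger change (an 8.2-fold higher number from compound 2 to compound 3 (0.91 log units; beyond the scatter)), and 3-fluoro-4-hydroxyphenyl in place of 2,3-dichlorophenyl gives a larger one still (a 36-fold higher number from compound 1 to compound 3 (1.56 log units; beyond the scatter)). Across these three compounds, both chlorine-bearing rings give lower numbers than the ring carrying fluorine and hydroxyl, and no compound shown goes against this order. Nothing measured here explains the rise.

Fluorine and hydroxyl enter together, so the compounds shown do not separate what each contributes. They also leave open how a 4-hydroxyphenyl ring without fluorine, or a ring carrying a methoxy group or an amine, would compare.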